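The source may hold more compounds than are shown below. What is called first, only, known or untested is meant among the compounds shown, and "the series" means these compounds.

Measured so far:
compound 1 `C=CCN(Cc1ccc2nc(C)[nH]c(=O)c2c1)c1ccc(C(=O)N[C@@H](CCC(=O)O)C(=O)O)cc1F` gives 5160 nM
compound 2 `Cc1nc2ccc(CN(CC(N)=O)c3ccc(C(=O)N[C@@H](CCC(=O)O)C(=O)O)c(F)c3)cc2c(=O)[nH]1` gives 1340 nM

Both results come from an assay on isolated protein for inhibition of Thymidylate synthase (Mus musculus); on this read-out higher numbers stand for weaker inhibition and lower numbers for stronger inhibition. Of the two numbers, compound 2 has the lower one, and its gap to compound 1 lies beyond the scatter, so compound 2 is the stronger inhibitor of the pair.

Compound 3 `C#CCN(Cc1ccc2nc(C)[nH]c(=O)c2c1)c1ccc(C(=O)N[C@@H](CCC(=O)O)C(=O)O)c(F)c1` has not yet been measured. It differs from compound 2 in one place: ethynyl in place of carbamoyl on a saturated chain carbon bound to a nitrogen on an aromatic ring. Among the measured compounds shown here, no measured pair shows this change, so its effect is unknown. Compound 1, which carries a chain of similar size at the same nitrogen, gives the weaker value, but it is not a direct comparison.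

Compound 3 is therefore expected to land near compound 2, with a step of a 1.1-fold lower number from compound 2 to compound 3 (0.05 log units; within the scatter) in this assay that could fall either way, and an estimate of 1200 nM (from 250 nM to 6000 nM).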

Compound 3, half-maximal inhibitory concentration: 20 nM
Estimate against measurement, compound 3: 60-fold (1.78 log units) above, and the stated range ends above it.
By their numbers in this assay, from the lowest: compound 3; then compound 2; then compound 1.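

Among the compounds shown here, this is the first direct look at this position, as compounds 1 and 2 differ in more than one place. In this assay, ethynyl in place of carbamoyl on a saturated chain carbon bound to a nitrogen on an aromatic ring gives a 67-fold lower number from compound 2 to compound 3 (1.83 log units; beyond the scatter), so this one small group can strongly change inhibition. No measurement here explains why the change has so large an effect.

The change removes carbamoyl and brings in a triple bond at once, so the compounds shown cannot tell which of the two events matters. From the compounds shown here alone, how a saturated propyl chain, a longer chain with a triple bond, an amine or a carboxylic acid would behave at this place also remains open.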